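A few compounds are considered here, and "the series" means these few. Any claim that something is new, unique, unknown or untested is made for them only; others in the source may bear on it.

Measured so far in a functional assay on MDA-MB-435S cells (Homo sapiens) for antiproliferative activity, read by MTT assay, with a stated time of 72 h; a lower number here means a stronger inhibitor, a higher number a weaker inhibitor: compound 1 `O=c1c(CSC(=S)N2CCN(c3ccccc3)CC2)coc2ccccc12` gives 9700 nM, compound 2 `CN1CCN(C(=S)SCc2coc3ccccc3c2=O)CC1` gives 2200 nM, and compound 3 `Cc1ccc2c(=O)c(CSC(=S)N3CCCC3)coc2c1` gives 1900 nM.

Among these three numbers compound 2 stands second highest. Its nearest neighbour is compound 3, whose value lies within the scatter of it, so no order between them can be claimed. Compound 1 lies furthest away, because a 4.4-fold lower number from compound 1 to compound 2 (0.64 log units; beyond the scatter).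

Compound 4 `CC(C)N(C(=S)SCc1coc2ccccc2c1=O)C(C)C` differs from compound 2 in one place: diisopropylamino in place of 4-methylpiperazin-1-yl on a thiocarbonyl carbon. Among the measured compounds shown here, the only measured step that touches the group on the thiocarbonyl carbon is the change from compound 1 to compound 2, and it was modest. A step of no more than that size, in either direction, is therefore expected in this assay. Compound 4 is estimated at 2500 nM, within 800 nM to 8000 nM, which means an expected step of a 1.1-fold higher number from compound 2 to compound 4 (0.06 log units; within the scatter).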

Compound 4, half-maximal inhibitory concentration: 7900 nM
Beside the measured number, compound 4's estimate is 3.2-fold (0.50 log units) below it; the measured number falls inside the stated range.
By their numbers in this assay, from the lowest: compounds 3 and 2 (each within the scatter of the next); then compounds 4 and 1 (each within the scatter of the next).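

In this assay there is a 3.6-fold higher number from compound 2 to compound 4 (0.56 log units; beyond the scatter) on replacing 4-methylpiperazin-1-yl with diisopropylamino, although both groups have the same count of heavy atoms. The earlier step changed only a group on the ring nitrogen, whereas this one shows that removing the ring altogether also shifts the number beyond the scatter. No measurement shown explains this shift.

On these data alone, whether the ring itself matters remains open, as does the role of the second ring nitrogen. A morpholin-4-yl or dimethylamino group on the thiocarbonyl carbon would bear on both questions.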